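The source may hold more compounds than are shown below. What is called first, only, known or untested is meant among the compounds shown, and "the series" means these compounds.

Measured in a functional assay on NCI-H1993 cells (Homo sapiens) for inhibition, read by CCK-8 assay, with a stated time of 72 h; on this read-out higher numbers stand for weaker inhibition and lower numbers for stronger inhibition:
- Compound 1 `CN(C)c1cccc(-c2cnc3ncn(Cc4ccc5ncccc5c4)c3n2)c1`: > 10000 nM, a limit of the assay
- Compound 2 `c1cnc2ccc(Cn3cnc4ncc(-c5ccncc5)nc43)cc2c1`: 1160 nM
- Compound 3 `FC(F)(F)c1ccc(-c2cnc3ncn(Cc4ccc5ncccc5c4)c3n2)cc1`: > 10000 nM, a limit of the assay

Compound 3 has no exact number and sits at the limit of > 10000 nM in this assay, at which 2 of the 3 values shown sit. Compound 4 `C1=C(c2cnc3ncn(Cc4ccc5ncccc5c4)c3n2)CCNC1` keeps the shared core but changes the group on its aromatic carbon: a group of 6 heavy atoms (5 carbon, 1 nitrogen; one six-membered non-aromatic ring with 1 hetero atom) in place of a group of 10 heavy atoms (7 carbon, 3 fluorine; one six-membered aromatic ring of carbon only), on an aromatic carbon.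

For the measured compounds named here, two measured steps bear on this change, and both lie beyond the scatter: an at least 8.6-fold lower number from compound 1 to compound 2 (0.93 log units; beyond the scatter) and an at least 8.6-fold higher number from compound 2 to compound 3 (0.93 log units; beyond the scatter). The step between the two limited compounds cannot be read. Of the three groups tried at this place, only the pyridin-4-yl of compound 2 gave a number, and compound 2 gives 1160 nM. The entering group also holds a ring nitrogen, though in a non-aromatic ring, so a move towards stronger inhibition is expected, of modest size and with real uncertainty. The expected change is an at least 4.0-fold lower number from compound 3 to compound 4 (0.60 log units; beyond the scatter). For compound 4 the estimated value is 2500 nM, with an expected range from 500 nM to 10000 nM.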

Compound 4, half-maximal inhibitory concentration: 6660 nM
Estimate against measurement, compound 4: 2.7-fold (0.43 log units) below, and the stated range covers the measured number.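

In this assay compound 4 joins compound 2 in giving a number at this position, so a group with a ring nitrogen need not be aromatic for a number to appear. Against the two groups without a ring nitrogen, the gain can be given only as a floor, with an at least 1.5-fold lower number from compound 3 to compound 4 (0.17 log units; that floor lies within the scatter) and an at least 1.5-fold lower number from compound 1 to compound 4 (0.17 log units; that floor lies within the scatter) as the two readings. The pyridin-4-yl group stays ahead, with a 5.7-fold higher number from compound 2 to compound 4 (0.76 log units; beyond the scatter) on going to the non-aromatic ring.

Compound 1 and compound 3 each remain a limit of the assay and not a number: the limit of > 10000 nM in this assay, at which 2 of the 4 values shown sit. Open too, going by these compounds, is how a fully saturated piperidine, a morpholine, a pyridin-3-yl group or a methyl group on the ring nitrogen would read at this position.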